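The source may hold more compounds than are shown below. What is called first, only, known or untested is meant among the compounds shown, and "the series" means these compounds.

Measured compounds:
compound 1, `Cc1ccc(S(=O)(=O)NCCCNc2nccc(-c3c(-c4cccc(F)c4)nc4sccn34)n2)cc1`, 8380 nM
compound 2, `O=S(=O)(NCCCNc1nccc(-c2c(-c3cccc(F)c3)nc3sccn23)n1)c1ccccc1`, 6600 nM
compound 3, `O=S(=O)(NCCNc1nccc(-c2c(-c3cccc(F)c3)nc3sccn23)n1)c1ccc(Cl)cc1`, 18600 nM

All three were run in a functional assay on A-375 cells (Homo sapiens) for cytotoxicity, read by MTT assay; on this read-out higher numbers stand for weaker inhibition and lower numbers for stronger inhibition. Compound 3 stands at the high end of the three numbers: the step of a 2.2-fold higher number from compound 1 to compound 3 (0.35 log units; beyond the scatter) and the step of a 2.8-fold higher number from compound 2 to compound 3 (0.45 log units; beyond the scatter) both lie beyond the scatter, whereas compounds 1 and 2 sit within the scatter of each other, as the step of a 1.3-fold lower number from compound 1 to compound 2 (0.10 log units; within the scatter) shows.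

Compound 4, `O=S(=O)(NCCCNc1nccc(-c2c(-c3cccc(F)c3)nc3sccn23)n1)c1ccc(F)cc1`, has not been measured. It differs from compound 3 by (((4-fluorophenyl)sulfonyl)amino)methyl in place of ((4-chlorophenyl)sulfonyl)amino on a saturated chain carbon, two bonds along the chain from a nitrogen on an aromatic ring. The two steps that bear on this are the ones that lead into compound 3 from the compounds bearing the longer chain, a 2.2-fold higher number from compound 1 to compound 3 (0.35 log units; beyond the scatter) and a 2.8-fold higher number from compound 2 to compound 3 (0.45 log units; beyond the scatter); both were modest rises and both ran toward the shorter-chain compound. The change to compound 4 runs the other way, back to the longer chain, with a fluorine on the aromatic ring in place of the chlorine. Going by the values given here, no measured pair isolates the halogen swap on its own, so that part is taken as neutral. A modest fall in this assay is therefore expected for compound 4, a 2.5-fold lower number from compound 3 to compound 4 (0.39 log units; beyond the scatter), landing it near compounds 1 and 2. The estimate for compound 4 is 7500 nM, with a range from 3500 nM to 16000 nM.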

Compound 4, half-maximal inhibitory concentration: 14500 nM
Compound 4: middle estimate off by 1.9-fold (0.29 log units), on the low side; the measured number falls inside the stated range.
By their numbers in this assay, from the lowest: compounds 2, 1, 4 and 3 (each within the scatter of the next, the first and the last beyond it).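

Working notes on the series: in this assay, putting (((4-fluorophenyl)sulfonyl)amino)methyl in place of ((4-chlorophenyl)sulfonyl)amino on the saturated chain carbon gives a 1.3-fold lower number from compound 3 to compound 4 (0.11 log units; within the scatter), so the distance of the shorter-chain compound from the two other longer-chain compounds does not reappear as a difference here, and chain length alone does not account for that distance. The aromatic carbon, which looked silent when hydrogen replaced methyl, now responds to one substituent: fluoro in place of hydrogen gives a 2.2-fold higher number from compound 2 to compound 4 (0.34 log units; beyond the scatter), while fluoro in place of methyl gives a 1.7-fold higher number from compound 1 to compound 4 (0.24 log units; within the scatter), so only the fluoro and hydrogen compounds stand apart at this position. Nothing available on these compounds explains either result.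

The chain change and the halogen change arrive together in the step into the fluoro compound, so their separate contributions remain unresolved, as does the effect of chloro on the longer chain. Also open, on these data alone, are the response to a methoxy group or a carboxylic acid on that aromatic carbon and the response to a longer chain, such as a four-carbon linker.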